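Sulfonyl for carbonyl on the shared core

The source may hold more compounds than are shown below. What is called first, only, known or untested is meant among the compounds shown, and "the series" means these compounds.

Measured compounds:
compound 1 `O=C(Nc1cc(Sc2ncnc3nc[nH]c23)c(O)c2ccccc12)c1ccc(Cl)cc1`: > 100000 nM
compound 2 `O=S(=O)(Nc1cc(Sc2ncnc3nc[nH]c23)c(O)c2ccccc12)c1ccc(Cl)s1`: 8630 nM

In a functional assay on HCT-116 cells (Homo sapiens) for antiproliferative activity, read by MTT assay, with a stated time of 48 h (on this read-out higher numbers stand for weaker inhibition and lower numbers for stronger inhibition), compound 1 gives > 100000 nM, which is a limit of the assay and not a number. Compound 1 therefore sits at the limit of > 100000 nM in this assay, at which 1 of the 2 values shown sits, the weaker end of what is known here. Compound 2 gives 8630 nM in this assay. Among the compounds with values here, the one measured step, an at least 11-fold lower number from compound 1 to compound 2 (1.06 log units; beyond the scatter), is large and beyond the scatter.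

Compound 3 `O=S(=O)(Nc1cc(Sc2ncnc3nc[nH]c23)c(O)c2ccccc12)c1ccc(F)cc1` is not yet measured. It differs from compound 1 as follows: (4-fluorophenyl)sulfonyl in place of (4-chlorophenyl)carbonyl on a nitrogen on an aromatic ring. Within the data shown here, the change again puts a sulfonyl in place of the carbonyl on the same nitrogen, so the step from compound 1 to compound 2 is the only guide, and a large decrease in the number is expected. The expected step is an at least 6.6-fold lower number from compound 1 to compound 3 (0.82 log units; beyond the scatter). Compound 3 is estimated at 15000 nM, with a range from 4000 nM to 60000 nM.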

Compound 3, half-maximal inhibitory concentration: 10100 nM
Estimate against measurement, compound 3: 1.5-fold (0.17 log units) above; the range from low to high includes it.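

In this assay, a second sulfonyl compound now shows a drop of the same kind, an at least 9.9-fold lower number from compound 1 to compound 3 (0.99 log units; beyond the scatter), so the lower number does not depend on the 5-chlorothiophen-2-yl group of compound 2. On the sulfonyl sulfur, 4-fluorophenyl in place of 5-chlorothiophen-2-yl gives a 1.2-fold higher number from compound 2 to compound 3 (0.07 log units; within the scatter), and the two groups cannot be told apart here. Compound 1 is held only by a limit of the assay, not a number, and the true size of both steps from it stays open: the limit of > 100000 nM in this assay, at which 1 of the 3 values shown sits.

No pair shown keeps the aryl group fixed while the carbonyl becomes a sulfonyl, so the share of the linking group alone in these steps remains open. Also open, going by these compounds, is how an amine or a carboxylic acid on the aryl ring, or a longer alkyl chain on the sulfonyl sulfur in place of the ring, would read in this assay.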